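A few compounds are considered here, and "the series" means these few. Any claim that something is new, unique, unknown or untested is made for them only; others in the source may bear on it.

Of the compounds shown here, three have been measured in a functional assay on A-375 cells (Homo sapiens) for antiproliferative activity, read by MTT assay, with a stated time of 24 h, tested at 0.05 ug/mL; on this read-out higher numbers stand for a stronger effect at the one concentration tested and lower numbers for a weaker effect. Compound 1 `Cc1c(C(=O)Nc2c(F)cc(-c3cccc(F)c3)cc2F)nc2ccc(OC(F)(F)F)cc2c1O` gives -0.13%. Compound 2 `Cc1c(C(=O)Nc2ccc(-c3ccccc3)cc2)nc2ccccc2c1O` gives 1.05%. Compound 3 `Cc1c(C(=O)Nc2c(F)cc(-c3cccc(F)c3)cc2F)nc2ccc(F)cc2c1C(=O)O` gives 0.37%. All three numbers sit near zero, and compound 2 stands within the usual scatter of both compound 1 and compound 3, so none of the three can be told apart on these readings.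

Compound 4 `Cc1c(C(=O)Nc2ccc(-c3ccccc3)cc2)nc2ccccc2c1C(=O)O` has not yet been measured in this assay. It differs from compound 2 by carboxy in place of hydroxy on an aromatic carbon. Compound 3 also bears a carboxy group, though in a different setting, and gives 0.37%. The step of a number 0.6 percentage points lower from compound 2 to compound 4 (within the scatter) is therefore expected to be none beyond the scatter. Compound 4 is estimated at 0.5%, with a range from -4% to 5%.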

Compound 4, a percentage reported as inhibition, at one concentration (the size of the read-out at that concentration, not a potency): 0.87%
Beside the measured number, compound 4's estimate is 0.4 percentage points below it; the range from low to high includes it.
By their numbers in this assay, from the lowest: compounds 1, 3, 4 and 2 (each within the scatter of the next).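

In this assay, among the compounds shown here, carboxy in place of hydroxy on the aromatic carbon opposite the ring nitrogen gives a number 0.2 percentage points lower from compound 2 to compound 4 (within the scatter) in the first matched pair of the series. At this position, the exchange therefore produces no change that can be read, and both compounds remain near zero at the one concentration tested. No measured data here offer an explanation for this result.

From the compounds shown here alone, whether an amine or a methoxy group on this carbon would move the reading beyond the scatter remains open. Going by these compounds, whether hydroxy and carboxy would differ at a higher concentration also remains open.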